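A Tail Change on a Shared Core

The source may hold more compounds than are shown below. What is called first, only, known or untested is meant among the compounds shown, and "the series" means these compounds.

Compound 2 `Cn1c(-c2ccc(NC(=O)CSc3nc4cc(Cl)ccc4o3)cc2)nc(-c2ccccc2)c1-c1ccccc1` is one of three compounds tested in a functional assay on MCF7 cells (Homo sapiens) for cytotoxicity, read by MTT assay, with a stated time of 24 h, tested at 0.64 ug/mL; on this read-out lower numbers stand for a weaker effect and higher numbers for a stronger effect at the one concentration tested. There compound 2 gives 2.4%, the second highest of the three numbers, though all three lie within the scatter of one another: compound 1 `Cn1c(-c2ccc(NC(=O)CCl)cc2)nc(-c2ccccc2)c1-c1ccccc1` gives 3.4% and compound 3 `CN1CCN(CC(=O)Nc2ccc(-c3nc(-c4ccccc4)c(-c4ccccc4)n3C)cc2)CC1` gives 1.1%. Compound 4 `CN(C)/C=C/N1CCN(CC(=O)Nc2ccc(-c3nc(-c4ccccc4)c(-c4ccccc4)n3C)cc2)CC1` differs from compound 2 in one place: 4-(2-(dimethylamino)ethenyl)piperazin-1-yl in place of (5-chloro-1,3-benzoxazol-2-yl)sulfanyl on a saturated chain carbon bound to a carbonyl carbon. The measured steps at this same place were all small: a number 1 percentage points lower from compound 1 to compound 2 (within the scatter), a number 2.3 percentage points lower from compound 1 to compound 3 (within the scatter) and a number 1.3 percentage points lower from compound 2 to compound 3 (within the scatter). Since each of these stayed within the scatter, no step beyond the scatter is expected for this change either. Compound 4 is therefore expected to give 1.5%, between 0% and 6%, an expected step of a number 0.9 percentage points lower from compound 2 to compound 4 (within the scatter).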

Compound 4, a percentage reported as activity, at one concentration (the size of the read-out at that concentration, not a potency): 1.2%
Compound 4: middle estimate off by 0.3 percentage points, on the high side; the range from low to high includes it.
By their numbers in this assay, from the lowest: compounds 3, 4, 2 and 1 (each within the scatter of the next).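

In this assay, going by these compounds alone, a fourth and quite different group on this saturated chain carbon bound to a carbonyl carbon, 4-(2-(dimethylamino)ethenyl)piperazin-1-yl, again stays close to the earlier compounds (a number 1.2 percentage points lower from compound 2 to compound 4 (within the scatter); a number 2.2 percentage points lower from compound 1 to compound 4 (within the scatter)). The result also adds a change further out on the tail, 2-(dimethylamino)ethenyl in place of methyl on an amine nitrogen in a ring, and that change too is small (a number 0.1 percentage points higher from compound 3 to compound 4 (within the scatter)). Nothing available explains these numbers.

Going by these compounds, whether a carboxylic acid or a morpholin-4-yl group at this place would move the number beyond the scatter stays open. On these data alone, how these compounds compare at other concentrations also stays open.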